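The source may hold more compounds than are shown below. What is called first, only, known or untested is meant among the compounds shown, and "the series" means these compounds.

In an ADME assay on Vero 76 cells (Chlorocebus sabaeus) for cytotoxicity, read by MTT assay, with a stated time of 96 h (a lower number here means that less compound is tolerated, a higher number that more compound is tolerated), the three measured compounds stand as follows.
Compound 1, `FC(F)(F)c1ccc(NCc2cn(-c3ccccc3)nc2-c2ccc(Br)cc2)cc1`, gives 28000 nM.
Compound 2, `Cc1ccc(-c2nn(-c3ccccc3)cc2CNc2ccc(C(F)(F)F)cc2)cc1`, gives 45000 nM.
Compound 3, `Cc1ccc(NCc2cn(-c3ccccc3)nc2-c2ccc(C)cc2)cc1`, reaches only a limit of the assay, > 100000 nM.

Of the two plain numbers, compound 2 holds the higher one, but compound 1 sits within the scatter of it, so the two cannot be told apart. Compound 4, `FC(F)(F)c1ccc(NCc2cn(-c3ccccc3)nc2-c2ccc(Cl)cc2)cc1`, is not yet measured; from compound 2 it differs by chloro in place of methyl on an aromatic carbon. Among the measured compounds shown here, one measured step concerns this same place: a 1.6-fold higher number from compound 1 to compound 2 (0.21 log units; within the scatter). That was a swap of a halogen for methyl, and compound 4 carries the reverse swap, chloro in place of methyl. The step of an at least 2.2-fold higher number from compound 2 to compound 3 (0.34 log units; beyond the scatter) touches a different place and does not speak to this change. Because the step of a 1.6-fold higher number from compound 1 to compound 2 (0.21 log units; within the scatter) stayed within the scatter, only a small move is expected here, leaning to a lower number, as a 1.5-fold lower number from compound 2 to compound 4 (0.18 log units; within the scatter). Compound 4 is therefore estimated at 30000 nM, expected to fall between 15000 nM and 60000 nM.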

Compound 4, half-maximal cytotoxic concentration: 18000 nM
Compound 4: middle estimate off by 1.7-fold (0.22 log units), on the high side; measured number inside the range.
By their numbers in this assay, from the lowest: compounds 4, 1 and 2 (each within the scatter of the next, the first and the last beyond it). At a limit, above all of these: compound 3.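

In this assay the swap from 4-methylphenyl to 4-chlorophenyl gives a change beyond the scatter (a 2.5-fold lower number from compound 2 to compound 4 (0.40 log units; beyond the scatter)), whereas the earlier step between bromo and methyl at this position stayed within it. Chloro and bromo cannot be told apart here (a 1.6-fold lower number from compound 1 to compound 4 (0.19 log units; within the scatter)), and compound 1, with bromo, lies within the scatter of both compound 2 and compound 4, so only the chloro and methyl pair separates at this position. Nothing measured here speaks to why this swap moves the number.

Only methyl and two halogens are shown at this position, so it stays open how an amine, a carboxylic acid or a longer chain would fare there. Also open, on these data alone, is how chloro would fare alongside the other methyl of compound 3, which stands at a limit of the assay (> 100000 nM).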